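Shifting the aryl group on the pyrazoline carbon of compound 3

This account rests on a few compounds, and the source may have more. Where it says the series, first, only, none or still open, it means among the compounds named here.

Of the compounds shown here, three sharing one core have been measured in a functional assay on the whole organism (strain albino) for inhibition, with Rattus norvegicus as the target, read by paw edema, with stated times of 1 h and 2 h, at a dose of 200 mg/kg by the oral route; on this read-out lower numbers stand for less inhibition and higher numbers for more inhibition at the one dose given (going by the name of the read-out). Compound 1 `O=c1oc2ccccc2cc1C1=NN(c2ccccc2)[C@@H](c2ccccc2)C1` gives 27.2%. Compound 2 `COc1cccc([C@H]2CC(c3cc4ccccc4oc3=O)=NN2c2ccccc2)c1` gives 38.3%, and compound 3 `O=c1oc2ccccc2cc1C1=NN(c2ccccc2)[C@@H](c2ccc(F)cc2)C1` gives 44.9%. The two substituted members sit above the unsubstituted one: a number 11.1 percentage points higher from compound 1 to compound 2 (beyond the scatter) and a number 17.7 percentage points higher from compound 1 to compound 3 (beyond the scatter). Between the two substituted members the gap is small, a number 6.6 percentage points higher from compound 2 to compound 3 (within the scatter), so compound 3 has the highest number of the three but cannot be separated from compound 2, while it stands clearly apart from compound 1.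

Compound 4 `O=c1oc2ccccc2cc1C1=NN(c2ccccc2)[C@@H](c2ccccc2[N+](=O)[O-])C1` is the next member. Its change from compound 3 is 2-nitrophenyl in place of 4-fluorophenyl on a saturated ring carbon. Within the data shown here, the only measured step at this same saturated ring carbon is the one from compound 2 to compound 3, an exchange of one substituted phenyl for another, and it stayed within the scatter. Among the measured compounds shown here, the steps from compound 1 show that adding a group to that phenyl raised the number modestly, but no measured compound carries a 2-nitrophenyl, so the direction of this particular change is unknown. Compound 4 is therefore expected to stay close to compound 3, with a number 3.9 percentage points lower from compound 3 to compound 4 (within the scatter) taken as essentially no step beyond the scatter. The estimate for compound 4 in this assay is 41%, expected to fall between 28% and 54%.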

Compound 4, a percentage reported as inhibition, in the whole organism at one dose (the size of the read-out at that dose, not a potency): 24.7%
Compound 4: middle estimate off by 16.3 percentage points, on the high side, outside the stated range (below it).
By their numbers in this assay, from the lowest: compounds 4 and 1 (each within the scatter of the next); then compounds 2 and 3 (each within the scatter of the next).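

In this assay, among these compounds, exchanging one substituted phenyl for another at this saturated ring carbon, which had looked silent among the earlier compounds, now gives steps beyond the scatter: a number 20.2 percentage points lower from compound 3 to compound 4 (beyond the scatter) and a number 13.6 percentage points lower from compound 2 to compound 4 (beyond the scatter). Nitro in place of hydrogen gives a number 2.5 percentage points lower from compound 1 to compound 4 (within the scatter), so the rise seen with compounds 2 and 3 over compound 1 does not hold for compound 4, and placing a group on this phenyl does not by itself raise the number. Nothing at hand accounts for the fall from the 4-fluorophenyl to the 2-nitrophenyl.

Compounds 2, 3 and 4 each carry a different group at a different place on the phenyl, so these compounds cannot separate the effect of the group from the effect of where it sits. As far as these compounds go, how an amine or a carboxylic acid on this phenyl would read also remains open, as does whether a second group on the same ring would change the number.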